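Compound 3 Against Two Measured Neighbours

This account rests on a few compounds, and the source may have more. Where it says the series, first, only, none or still open, it means among the compounds named here.

Compound 1 `COc1cc(C(=O)c2sc(-c3ccc(Br)cc3)cc2N)cc(OC)c1OC` gives 150 nM
Compound 2 `COc1cc(C(=O)c2sc(-c3ccc(Cl)c(Cl)c3)cc2N)cc(OC)c1OC` gives 400 nM

Going by the values given here, both numbers come from a functional assay on FM3A cells (Mus musculus) for antiproliferative activity (on this read-out higher numbers stand for weaker inhibition and lower numbers for stronger inhibition), where compound 2 is the higher of the two, with a 2.7-fold higher number from compound 1 to compound 2 (0.43 log units; beyond the scatter) as the only measured step. That step, 3,4-dichlorophenyl in place of 4-bromophenyl on an aromatic carbon, is modest. Compound 3 `COc1cccc(-c2cc(N)c(C(=O)c3cc(OC)c(OC)c(OC)c3)s2)c1` is not yet measured and changes the same carbon again, with 3-methoxyphenyl in place of 3,4-dichlorophenyl on an aromatic carbon on a carbon next to the ring sulfur. Among the compounds with values here, no measured compound carries a methoxy group at this place, so the one step is the only guide. Within the data shown here, with compound 1 at 150 nM as the only other group measured there, a step smaller than the measured one and toward a lower number is expected. Estimated for this change is a 1.8-fold lower number from compound 2 to compound 3 (0.26 log units; within the scatter) in this assay with the direction far from certain. Compound 3 is estimated at 220 nM within an expected range of 60 nM to 800 nM on this read-out.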

Compound 3, half-maximal inhibitory concentration: 36 nM
The estimate for compound 3 lay 6.1-fold (0.79 log units) above the measured number; measured number below the stated range.
By their numbers in this assay, from the lowest: compound 3; then compound 1; then compound 2.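

In this assay, the aromatic carbon next to the ring sulfur turns out to be far more sensitive to the choice of phenyl group than the two halogen-bearing compounds had indicated: 3-methoxyphenyl in place of 3,4-dichlorophenyl gives an 11-fold lower number from compound 2 to compound 3 (1.05 log units; beyond the scatter), and in place of 4-bromophenyl it gives a 4.2-fold lower number from compound 1 to compound 3 (0.62 log units; beyond the scatter). A phenyl group without halogen therefore gives the lowest number of the three here, although the 3,4-dichlorophenyl and 3-methoxyphenyl groups have the same count of heavy atoms. Nothing available bears on why the number falls with this change.

Compound 3 differs from compound 1 both in the group on the phenyl ring and in where it stands, and the compounds shown do not separate these two changes. Going by these compounds, whether a hydroxy group, an amine or a longer ether chain could take the place of the methoxy group also remains open.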